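The source may report more compounds than this note shows. Statements on the series, on what has been measured and on what is new or still open speak of the compounds shown alone.

Compound 1 `COc1ccccc1N1CCN(CC(=O)N2CCN(c3nnc(-c4ccc(Cl)cc4)c(-c4ccc(Cl)cc4)n3)CC2)CC1`: 330000 nM
Compound 2 `COc1ccc(N2CCN(CC(=O)N3CCN(c4nnc(-c5ccc(Cl)cc5)c(-c5ccc(Cl)cc5)n4)CC3)CC2)cc1`: > 809000 nM

In a functional assay on MCF7 cells (Homo sapiens) for cytotoxicity, read by MTT assay, with a stated time of 24 h (a higher number here means a weaker inhibitor, a lower number a stronger inhibitor), compound 1 gives 330000 nM. Compound 2 gives only a limit in this assay, namely > 809000 nM, so its true number is not known. The step of an at least 2.4-fold higher number from compound 1 to compound 2 (0.38 log units; beyond the scatter) is accordingly only bounded, a consequence of the limit of > 809000 nM in this assay, at which 1 of the 2 values shown sits. Compound 3 `O=C(CN1CCN(c2ccc([N+](=O)[O-])cc2)CC1)N1CCN(c2nnc(-c3ccc(Cl)cc3)c(-c3ccc(Cl)cc3)n2)CC1` differs from compound 2 by nitro in place of methoxy on an aromatic carbon. Among the measured compounds shown here, no measured step concerns this kind of change: the single measured step moves a methoxy group from one place on the ring to another, and so it says nothing about replacing methoxy by nitro. Compound 2 stands at the limit of this assay, and compound 3 is expected to remain near that limit, with an at least 1.1-fold lower number from compound 2 to compound 3 (0.06 log units; that floor lies within the scatter) not beyond the scatter in either direction. Compound 3 is estimated at 700000 nM, between 200000 nM and 2000000 nM, with a real chance that this assay again reports only a limit.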

Compound 3, half-maximal inhibitory concentration: > 789000 nM
Compound 3: a limit, no number (the forecaster's own chance of this, stated with the estimate: 60%); middle value at least 1.1-fold (0.05 log units) away from the limit.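

In this assay compound 3 gives > 789000 nM, which is a limit and not a number. Placing 4-nitrophenyl where compound 1 carries 2-methoxyphenyl gives an at least 2.3-fold higher number from compound 1 to compound 3 (0.37 log units; beyond the scatter), which makes nitro the second group after the 4-methoxy group of compound 2 to read weaker than the 2-methoxyphenyl compound. The direct step from methoxy to nitro cannot be read, since both of its ends are limits, and compound 3 supplies one of them: the limit of > 789000 nM in this assay, at which 1 of the 3 values shown sits.

From the compounds shown here alone, how far the true numbers of compound 2 and compound 3 lie past their limits remains open, so the methoxy and nitro groups cannot be ranked against each other. Also open, going by these compounds, is whether a different group on this ring, such as an amine or a carboxylic acid, would give a measurable number in this assay.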